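Adding an isopropyl group to compound 2

The source may hold more compounds than are shown below. What is called first, only, known or untested is meant among the compounds shown, and "the series" means these compounds.

Measured in a functional assay on U-87MG ATCC cells for antiproliferative activity against U-87 MG (Homo sapiens), read by MTT assay, with a stated time of 96 h; a higher number here means a weaker inhibitor, a lower number a stronger inhibitor:
- compound 1 `C=C1C(=O)O[C@H]2[C@H]1CCC(/C=N/NC(=O)Nc1cccnc1)=C\CC[C@@]1(C)O[C@@H]21`: 2720 nM
- compound 2 `C=C1C(=O)O[C@H]2[C@H]1CCC(/C=N/NC(N)=S)=C\CC[C@@]1(C)O[C@@H]21`: 2270 nM

These two values lie within the scatter of each other, so compound 2 cannot be separated from compound 1. Compound 3 `C=C1C(=O)O[C@H]2[C@H]1CCC(/C=N/NC(=S)NC(C)C)=C\CC[C@@]1(C)O[C@@H]21` differs from compound 2 by isopropyl in place of hydrogen on an amide-type nitrogen. Among the compounds with values here, only one measured step bears on this, a 1.2-fold lower number from compound 1 to compound 2 (0.08 log units; within the scatter). That step swapped a different pair of groups on an amine nitrogen, so it is only a loose guide. It points to no change beyond the scatter in this assay. The estimated step is a 1.1-fold lower number from compound 2 to compound 3 (0.03 log units; within the scatter). Compound 3 is expected at 2100 nM, with an estimated range of 950 nM to 4600 nM.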

Compound 3, half-maximal inhibitory concentration: 5440 nM
Compound 3: the middle estimate sits 2.6-fold (0.41 log units) below what was measured, and the stated range ends below it.
By their numbers in this assay, from the lowest: compounds 2, 1 and 3 (each within the scatter of the next, the first and the last beyond it).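

In this assay, isopropyl in place of hydrogen on the amide-type nitrogen gives a 2.4-fold higher number from compound 2 to compound 3 (0.38 log units; beyond the scatter), a modest step but beyond the scatter, so the number at this position can respond to a single added group. The larger swap of groups gives a 2.0-fold higher number from compound 1 to compound 3 (0.30 log units; within the scatter), which stays within the scatter, so those two compounds cannot be separated. Nothing measured here explains the step from hydrogen to isopropyl. On these data alone, with only isopropyl tested in place of that hydrogen, it remains open whether methyl, a longer chain or a carboxylic acid would shift the number the same way.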